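Cytotoxicity notes: replacing the amide aryl in compound 1

A few compounds are considered here, and "the series" means these few. Any claim that something is new, unique, unknown or untested is made for them only; others in the source may bear on it.

Measured compounds:
- compound 1 `CC(C)n1ncc2c(C(=O)Nc3ccc(F)cc3)cc(-c3cccs3)nc21`: in an ADME assay on LLC-MK2 cells (Macaca mulatta) for cytotoxicity, read by spectrophotometry and crystal violet staining, with a stated time of 4 days (on this read-out higher numbers stand for lower toxicity in this test and lower numbers for higher toxicity in this test), compound 1 gives > 200000 nM, a limit of the assay rather than a number.
- compound 2 `CC(C)n1ncc2c(C(=O)N3CCc4cc(F)ccc43)cc(-c3cccs3)nc21`: compound 2 gives > 200000 nM, also only a limit.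
- compound 3 `CC(C)n1ncc2c(C(=O)Nc3ccc(F)cc3)cc(-c3ccco3)nc21`: compound 3 gives > 200000 nM, again a limit.

Compound 1 therefore stands only at a limit, as do the other two values shown; all three sit at the limit of > 200000 nM in this assay, at which 3 of the 3 values shown sit. For the measured compounds named here, the one measured single-point change, a step that the two limits leave unreadable from compound 1 to compound 3, cannot be sized from two limits. Compound 4 `CC(C)n1ncc2c(C(=O)Nc3ccccn3)cc(-c3cccs3)nc21` differs from compound 1 by pyridin-2-yl in place of 4-fluorophenyl on an amide-type nitrogen. Going by the values given here, no measured step bears on this change, so no step beyond the scatter is expected in this assay. Compound 4 is expected at 200000 nM (range 100000 nM to 400000 nM), most likely again reported as a limit, implying an expected step of a number no higher from compound 1 to compound 4 (the limit leaves the size open).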

Compound 4, half-maximal cytotoxic concentration: > 200000 nM
Compound 4 gave a limit, no number; the forecaster's own chance of this, stated with the estimate: 85%; the middle value lies on the limit itself.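

Compound 1 and compound 4 both give limits rather than numbers, and no step can be read between them: the limit of > 200000 nM in this assay, at which 4 of the 4 values shown sit. The compounds shown leave open whether pyridin-2-yl in place of 4-fluorophenyl on an amide-type nitrogen shifts the half-maximal cytotoxic concentration at all.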